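A few compounds are considered here, and "the series" means these few. Any claim that something is new, unique, unknown or untested is made for them only; others in the source may bear on it.

Measured compounds:
compound 1 `COc1ccc(-c2cnc3nc(N)nc(N4CCN(c5cc(Cl)cc(Cl)c5)CC4)c3n2)cc1OC`: 3400 nM
compound 2 `CCOc1nc(N)nc2ncc(-c3ccc(OC)cc3)nc12`: > 10000 nM

Both were tested in a functional assay on cells (T-cell, Homo sapiens) for inhibition; a lower number here means a stronger inhibitor, a higher number a weaker inhibitor. Compound 1 is the only one of the two with an actual number, giving 3400 nM. For compound 2 this assay reports only a limit, > 10000 nM, which is the limit of > 10000 nM in this assay, at which 1 of the 2 values shown sits. Among the compounds with values here, no step between these two compounds that changes a single place has been measured, so their two values stand side by side without further comparison.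

Compound 3 is `COc1ccc(-c2cnc3nc(N)nc(N4CCN(C(=O)Nc5ccc(F)cc5)CC4)c3n2)cc1OC` and has not yet been measured. It differs from compound 1 in one place: (4-fluorophenyl)carbamoyl in place of 3,5-dichlorophenyl on an amine nitrogen in a ring. No measured step of this kind exists among the compounds shown, so the expected change is modest, with no clear direction beyond the scatter. The step this estimate implies, a 1.1-fold lower number from compound 1 to compound 3 (0.05 log units; within the scatter), is expected to stay within that scatter. Compound 3 is therefore expected to give about 3000 nM, most likely between 800 nM and 12000 nM.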

Compound 3, half-maximal inhibitory concentration: 7 nM
Estimate against measurement, compound 3: 430-fold (2.63 log units) above; measured number outside the range, below it.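

In this assay, the group on the amine nitrogen in the six-membered non-aromatic ring proves to matter a great deal: (4-fluorophenyl)carbamoyl in place of 3,5-dichlorophenyl gives a 490-fold lower number from compound 1 to compound 3 (2.69 log units; beyond the scatter). The earlier compounds shown here could not show this, as they offered no step that changes a single place. Both groups carry a six-membered aromatic ring of carbon only, so the presence of such a ring at this place does not by itself set the value.

The exchange alters several features at once, so the compounds shown do not separate the carbonyl and the amide hydrogen from the swap of two chlorines for one fluorine; a phenylcarbamoyl group without fluorine, or a simple acetyl group, would pull these apart. No measurement shown bears on why this exchange has so large an effect.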